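This account rests on a few compounds, and the source may have more. Where it says the series, first, only, none or still open, it means among the compounds named here.

Measured in a functional assay on SK-MEL-2 cells (Homo sapiens) for inhibition, read by sulforhodamine B assay, with a stated time of 48 h; on this read-out lower numbers stand for higher toxicity in this test and higher numbers for lower toxicity in this test:
Compound 1 `COc1cc(-c2nn(-c3cccc(NC(=O)c4cccc(C(F)(F)F)c4)c3)cc2-c2ccncc2)ccc1Cl`: > 50000 nM, a limit of the assay and not a number
Compound 2 `COc1cc(-c2nn(-c3cccc(NC(=O)Nc4cccc(C(F)(F)F)c4)c3)cc2-c2ccncc2)ccc1Cl`: 3960 nM

Within the data shown here, compound 2 holds the only actual number in this assay, so it has no numerical neighbour to be ranked against. Compound 3 `COc1cc(-c2nn(-c3cccc(NC(=O)Nc4ccc(Cl)c(C(F)(F)F)c4)c3)cc2-c2ccncc2)ccc1Cl` differs from it by chloro in place of hydrogen on an aromatic carbon, ortho to a trifluoromethyl group and para to a large group (chloro in place of hydrogen on an aromatic carbon). Among the measured compounds shown here, the one measured step, an at least 12-fold lower number from compound 1 to compound 2 (1.10 log units; beyond the scatter), is large, but it concerns the change on the carbonyl carbon and not this ring. Compound 3 keeps the group gained in that step, so the starting point remains compound 2 at 3960 nM. For the measured compounds named here, no measured step covers chloro, so only a small change is expected, perhaps toward a slightly lower number, and possibly none beyond the scatter. The expected change is a 1.3-fold lower number from compound 2 to compound 3 (0.12 log units; within the scatter). For compound 3 the estimated value is 3000 nM, with an expected range of 1000 nM to 10000 nM.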

Compound 3, concentration lethal to 50% of the cells: 17500 nM
Beside the measured number, compound 3's estimate is 5.8-fold (0.77 log units) below it; measured number above the stated range.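

In this assay, chloro in place of hydrogen on the aromatic carbon ortho to the trifluoromethyl group gives a 4.4-fold higher number from compound 2 to compound 3 (0.65 log units; beyond the scatter), which shows that this position of the ring is not neutral and that this change runs towards lower toxicity in this test. Part of the gain from the change on the carbonyl carbon remains in the chloro-bearing compound, with an at least 2.8-fold lower number from compound 1 to compound 3 (0.45 log units; beyond the scatter) still to be read. Compound 1 stands at a limit of the assay and not at a number, so this last step is only a bound: the limit of > 50000 nM in this assay, at which 1 of the 3 values shown sits.

As far as these compounds go, whether the shift belongs to chloro itself or to any group on this carbon stays open, and fluoro, methyl or methoxy there would separate the two. Also open, from the compounds shown here alone, is how chloro would read on another carbon of this ring, or with the trifluoromethyl group replaced by a nitrile.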